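Replacing Bromo by Methyl on the Pendant Phenyl

The compounds below may be only part of what the source reports. "The series", "measured", "known", "first", "only" and "open" are said of these compounds alone.

Compound 1, `Cc1ccc(-c2c(S(=O)(=O)c3ccccc3)cnc3cc(C)nn23)cc1`, gives 23.2% in a functional assay on the whole organism for inhibition, with Mus musculus as the target, with a stated time of 3 h, at a dose of 50 mg/kg by the oral route; a higher number here means more inhibition at the dose given (going by the name of the read-out), a lower number less inhibition.
Compound 2, `Cc1ccc(-c2c(S(=O)(=O)c3ccccc3)cnc3cc(-c4ccccc4)nn23)cc1`, gives 36.4% in this assay.
Compound 3, `Cc1ccc(-c2c(S(=O)(=O)c3ccccc3)cnc3cc(-c4ccc(Br)cc4)nn23)cc1`, gives 69.2% in this assay.

Compound 3 stands highest of the three, with both gaps beyond the scatter: a number 46 percentage points higher from compound 1 to compound 3 (beyond the scatter) and a number 32.8 percentage points higher from compound 2 to compound 3 (beyond the scatter). Compound 4, `Cc1ccc(-c2cc3ncc(S(=O)(=O)c4ccccc4)c(-c4ccc(C)cc4)n3n2)cc1`, differs from compound 3 by methyl in place of bromo on an aromatic carbon. Among the compounds with values here, no measured step exchanges bromo for methyl. The nearest is a number 32.8 percentage points higher from compound 2 to compound 3 (beyond the scatter), where the whole bromo was introduced in place of hydrogen, and a number 13.2 percentage points higher from compound 1 to compound 2 (beyond the scatter). Methyl is neither hydrogen nor bromo, so a downward step of intermediate size is expected in this assay: a number 19.2 percentage points lower from compound 3 to compound 4 (beyond the scatter). Compound 4 is therefore estimated to give 50%, with a range from 28% to 72%.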

Compound 4, a percentage reported as inhibition, in the whole organism at one dose (the size of the read-out at that dose, not a potency): 31.2%
Compound 4: middle estimate off by 18.8 percentage points, on the high side, within the range that was stated.
By their numbers in this assay, from the lowest: compounds 1, 4 and 2 (each within the scatter of the next, the first and the last beyond it); then compound 3.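

Methyl does not carry the gain seen with bromo at this position: in this assay there is a number 38 percentage points lower from compound 3 to compound 4 (beyond the scatter) and, against the two lower compounds, a number 5.2 percentage points lower from compound 2 to compound 4 (within the scatter) and a number 8 percentage points higher from compound 1 to compound 4 (within the scatter) place compound 4 level with both. Among the groups shown, only bromo lifts the number at this place beyond the scatter, and methyl adds nothing measurable over hydrogen. Nothing available explains why bromo and methyl part so widely here. On these data alone, whether chloro, an amine or a carboxylic acid at this place would match compound 3 in this assay remains open.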